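A few compounds are considered here, and "the series" means these few. Any claim that something is new, unique, unknown or untested is made for them only; others in the source may bear on it.

The three compounds measured so far, with their values in a functional assay on MCF7 cells (Homo sapiens) for antiproliferative activity, read by MTT assay, with a stated time of 72 h; a higher number here means a weaker inhibitor, a lower number a stronger inhibitor:
compound 1 `O=C(Nc1ccc(Cl)c(-c2nnc3c(Cl)cccn23)c1)c1cccc(Cl)c1` — compound 1 gives 71900 nM
compound 2 `O=C(Nc1ccc(Cl)c(-c2nnc3c(Cl)cccn23)c1)c1ccc(Cl)cc1` — compound 2 gives 58400 nM
compound 3 `O=C(Nc1ccc(Cl)c(-c2nnc3c(Cl)cccn23)c1)c1ccc(Cl)cc1Cl` — compound 3 gives 78200 nM

Compound 3 carries the nominally highest of the three numbers, yet the steps leading to it, a 1.1-fold higher number from compound 1 to compound 3 (0.04 log units; within the scatter) and a 1.3-fold higher number from compound 2 to compound 3 (0.13 log units; within the scatter), both fall within the scatter, so no real separation among the three is shown. Compound 4 `O=C(Nc1ccc(Cl)c(-c2nnc3c(Cl)cccn23)c1)c1cccnc1` is the next compound: pyridin-3-yl in place of 2,4-dichlorophenyl on a carbonyl carbon. All three measured steps, a 1.2-fold lower number from compound 1 to compound 2 (0.09 log units; within the scatter), a 1.1-fold higher number from compound 1 to compound 3 (0.04 log units; within the scatter) and a 1.3-fold higher number from compound 2 to compound 3 (0.13 log units; within the scatter), vary the aryl group on this same carbonyl carbon, and none of them moved the number beyond the scatter. For the measured compounds named here, no measured compound carries a pyridin-3-yl group, so that part of the change is untested. On this basis compound 4 is expected to stay close to compound 3, with an expected step of a 1.1-fold lower number from compound 3 to compound 4 (0.05 log units; within the scatter), not beyond the scatter. Compound 4 is therefore estimated at 70000 nM, with a range from 30000 nM to 160000 nM.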

Compound 4, half-maximal inhibitory concentration: > 100000 nM
Compound 4: no number, only a limit; the forecaster's own chance of this, stated with the estimate: 15%; middle value at least 1.4-fold (0.15 log units) from the limit.
By their numbers in this assay, from the lowest: compounds 2, 1 and 3 (each within the scatter of the next). At a limit, above all of these: compound 4.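

In this assay compound 4 gives > 100000 nM, which is a limit of the assay and not a number. Pyridin-3-yl is the first group on this carbonyl carbon with a hetero atom in its ring, and the steps it gives are an at least 1.2-fold higher number from compound 3 to compound 4 (0.10 log units; that floor lies within the scatter), an at least 1.7-fold higher number from compound 2 to compound 4 (0.23 log units; that floor lies within the scatter) and an at least 1.3-fold higher number from compound 1 to compound 4 (0.14 log units; that floor lies within the scatter), so this change shows no gain over the chlorinated phenyl groups, while each floor still lies within the scatter and no loss beyond it is established. The true size of the change therefore remains unknown, as the reading stops at a limit: the limit of > 100000 nM in this assay, at which 1 of the 4 values shown sits.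

The compounds shown leave open whether any group on this carbonyl carbon can move the number beyond the scatter, such as a non-aromatic morpholine or a phenyl ring bearing a carboxylic acid. They also leave open what happens when the chloro groups on the shared core are replaced, for example by an amine.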